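Swapping an imidazole for a tetrazole in a dioxolane series

The compounds below may be only part of what the source reports. "The series", "measured", "known", "first", "only" and "open" are said of these compounds alone.

Compound 1 `CCC(C)n1ncn(-c2ccc(N3CCN(c4ccc(OC[C@@H]5CO[C@@](CN6CCNCC6)(c6ccc(Cl)cc6Cl)O5)cc4)CC3)cc2)c1=O`: 608 nM
Compound 2 `CCc1nccn1C[C@@]1(c2ccc(Cl)cc2Cl)OC[C@@H](COc2ccc(N3CCN(c4ccc(-n5cnn(C(C)CC)c5=O)cc4)CC3)cc2)O1`: 224 nM
Compound 3 `CCC(C)n1ncn(-c2ccc(N3CCN(c4ccc(OC[C@@H]5CO[C@@](Cn6ccnc6-c6ccccc6)(c6ccc(Cl)cc6Cl)O5)cc4)CC3)cc2)c1=O`: 136 nM

In a functional assay on HUVEC cells (Homo sapiens), read by scintillation counting and thymidine incorporation, with a stated time of 24 h (a lower number here means a stronger inhibitor, a higher number a weaker inhibitor), compound 3 gives the lowest of the three numbers. Its nearest neighbour is compound 2, a step within the scatter of the method, so the two cannot be ranked; the step from compound 1 is larger, a 4.5-fold lower number from compound 1 to compound 3 (0.65 log units; beyond the scatter), and clear.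

Compound 4 `CCC(C)n1ncn(-c2ccc(N3CCN(c4ccc(OC[C@@H]5CO[C@@](Cn6nnnc6-c6ccccc6)(c6ccc(Cl)cc6Cl)O5)cc4)CC3)cc2)c1=O` is compound 3 with one change: 5-phenyl-1H-tetrazol-1-yl in place of 2-phenyl-1H-imidazol-1-yl on a saturated chain carbon bound to a saturated ring carbon

Among the measured compounds shown here, no measured pair tests this exact change. For the measured compounds named here, the steps that bear on it are those at the same place: a 2.7-fold lower number from compound 1 to compound 2 (0.43 log units; beyond the scatter) and a 4.5-fold lower number from compound 1 to compound 3 (0.65 log units; beyond the scatter), both showing that an azole carrying a small group at this position gives a lower number than the open piperazine. Between the two azoles themselves, a 1.6-fold lower number from compound 2 to compound 3 (0.22 log units; within the scatter) is within the scatter. A tetrazole keeps the azole pattern and the phenyl, so for compound 4 the expected step in this assay is small, a 1.3-fold higher number from compound 3 to compound 4 (0.12 log units; within the scatter), in either direction or none beyond the scatter. Compound 4 is therefore estimated at 180 nM, with a range from 70 nM to 450 nM.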

Compound 4, half-maximal inhibitory concentration: 119 nM
Estimate against measurement, compound 4: 1.5-fold (0.18 log units) above; the range from low to high includes it.
By their numbers in this assay, from the lowest: compounds 4, 3 and 2 (each within the scatter of the next); then compound 1.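

In this assay the 5-phenyl-1H-tetrazol-1-yl group can stand in place of 2-phenyl-1H-imidazol-1-yl on this saturated chain carbon without a readable change (a 1.1-fold lower number from compound 3 to compound 4 (0.06 log units; within the scatter)), so an imidazole is not required here. The tetrazole also cannot be separated from the ethyl-bearing imidazole (a 1.9-fold lower number from compound 2 to compound 4 (0.27 log units; within the scatter)), while it stands clearly apart from the open piperazine (a 5.1-fold lower number from compound 1 to compound 4 (0.71 log units; beyond the scatter)), which makes compounds 2, 3 and 4 a set of azoles that all give lower numbers than compound 1. Nothing available explains why the two phenyl-bearing rings read alike.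

The compounds shown leave open what a tetrazole carrying a methyl group or a carboxylic acid instead of phenyl would give. Also open, from the compounds shown here alone, is whether a methoxy group on the phenyl ring would move the number.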